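The compounds below may be only part of what the source reports. "The series", "measured", "known", "first", "only" and "open" are said of these compounds alone.

Measured so far in an ADME assay on Vero cells (Chlorocebus sabaeus) for cytotoxicity, read by MTT assay, with a stated time of 72 h; on this read-out higher numbers stand for an effect only at larger amounts of compound and lower numbers for an effect already at smaller amounts:
compound 1 `Cc1cccc(C(=O)Nc2nc(-c3ccccn3)cs2)c1`: 4100 nM
compound 2 `O=C(Nc1nc(-c2ccccn2)cs1)c1cccc([N+](=O)[O-])c1`: "not determined" (no result reported)

Compound 2 has no single number to stand on, so the only numerical reference in the series is compound 1 at 4100 nM. Compound 3 `O=C(Nc1nc(-c2ccccn2)cs1)c1cccc(Br)c1` differs from compound 2 by one group: bromo in place of nitro on an aromatic carbon. Going by the values given here, no measured step shows what such a change does in this assay, so no step beyond the usual scatter is expected. Compound 3 is estimated at 4000 nM, with an expected range of 1500 nM to 12000 nM.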

Compound 3, half-maximal effective concentration: 16100 nM
The estimate for compound 3 lay 4.0-fold (0.60 log units) below the measured number, and the stated range ends below it.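

Going by these compounds alone, at this aromatic carbon the substituent moves the read-out in this assay: bromo in place of methyl gives a 3.9-fold higher number from compound 1 to compound 3 (0.59 log units; beyond the scatter) and so provides the first step beyond the scatter. The step from nitro to bromo cannot be read, since compound 2 has no number. Nothing at hand bears on the cause of the step from methyl to bromo.

Open, as far as these compounds go, is how an amine, a carboxylic acid or a longer chain on this same carbon would read, and whether the step from methyl to bromo holds elsewhere on the ring.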